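Replacing the 2-Iodophenyl Group: An Expected Small Step

A few compounds are considered here, and "the series" means these few. Any claim that something is new, unique, unknown or untested is made for them only; others in the source may bear on it.

Three amides on a shared core have been measured in a functional assay on HepG2 cells (Homo sapiens) for inhibition, read by MTT assay (on this read-out higher numbers stand for weaker inhibition and lower numbers for stronger inhibition), so far. Compound 3 (`COc1cc2ncnc(Nc3ccc(NC(=O)c4ccccc4I)cc3)c2cc1OC`) gives 33000 nM there and stands level with compound 2 (`COc1cc2ncnc(Nc3ccc(NC(=O)c4ccc(Cl)cc4)cc3)c2cc1OC`), which gives 28000 nM in the same test. The gap between them stays within the scatter (a 1.2-fold higher number from compound 2 to compound 3 (0.07 log units; within the scatter)). Compound 1 (`COc1cc2ncnc(Nc3ccc(NC(=O)c4ccccc4F)cc3)c2cc1OC`) gives 13000 nM and is set apart from both by modest steps (a 2.2-fold higher number from compound 1 to compound 2 (0.33 log units; beyond the scatter); a 2.5-fold higher number from compound 1 to compound 3 (0.40 log units; beyond the scatter)).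

Compound 4 (`COc1cc2ncnc(Nc3ccc(NC(=O)c4cc(F)ccc4Br)cc3)c2cc1OC`) carries 2-bromo-5-fluorophenyl in place of 2-iodophenyl on a carbonyl carbon. All three measured steps change the group at this same place, so all three bear on the new one. None of them is more than modest, and this suggests only a small move. Within the data shown here, compound 1 is the one measured compound with a fluoro group, and the step of a 2.5-fold higher number from compound 1 to compound 3 (0.40 log units; beyond the scatter) gives a weak lean towards a lower number for compound 4, although its fluoro group sits elsewhere on the ring. The expected step is a 1.5-fold lower number from compound 3 to compound 4 (0.18 log units; within the scatter) in this assay and may prove to be no real change at all. The estimated value for compound 4 is 22000 nM (expected range 10000 nM to 45000 nM).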

Compound 4, half-maximal inhibitory concentration: 22000 nM
Estimate against measurement, compound 4: no gap at the digits printed; measured number inside the range.
By their numbers in this assay, from the lowest: compounds 1, 4, 2 and 3 (each within the scatter of the next, the first and the last beyond it).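

Placing 2-bromo-5-fluorophenyl on the carbonyl carbon in place of 2-iodophenyl gives no change that can be told from the scatter in this assay (a 1.5-fold lower number from compound 3 to compound 4 (0.18 log units; within the scatter)), and the same holds against the 4-chlorophenyl amide (a 1.3-fold lower number from compound 2 to compound 4 (0.10 log units; within the scatter)). Among these compounds, what the earlier compounds did not show is that the 2-fluorophenyl amide need not stand apart from the other amides at this place, as its gap to this new group also stays within the scatter (a 1.7-fold higher number from compound 1 to compound 4 (0.23 log units; within the scatter)), so the only two readable steps so far now sit beside one that is not. Nothing measured on these compounds offers an explanation for this result.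

All four compounds carry only halogens on this ring, so they leave open whether an amine or a carboxylic acid there would move the number in this assay beyond the scatter. Going by these compounds, the bromo and fluoro groups of 2-bromo-5-fluorophenyl also enter together in a single step, so what each contributes alone remains open.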